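A few compounds are considered here, and "the series" means these few. Any claim that something is new, unique, unknown or untested is made for them only; others in the source may bear on it.

Measured compounds:
- compound 1 `N#CC1=C(N)N(c2ccc(S(N)(=O)=O)cc2)C2=C(CCCC2)C1c1ccccc1O`, with 100%
- compound 2 `COc1ccccc1C1C(C#N)=C(N)N(c2ccc(S(N)(=O)=O)cc2)C2=C1CCCC2`, with 100%
- compound 3 `COc1ccc(C2C(C#N)=C(N)N(c3ccc(S(N)(=O)=O)cc3)C3=C2CCCC3)cc1`, with 100%

All three were tested in a functional assay on Ehrlich cells (Mus musculus) for cytotoxicity, read by trypan blue exclusion, with a stated time of 2 h, tested at 100 ug/mL; a lower number here means a weaker effect, a higher number a stronger effect of the compound at the concentration tested. The three readings sit together at the top of the scale: the step of no change at the digits printed from compound 1 to compound 2 (within the scatter), the step of no change at the digits printed from compound 1 to compound 3 (within the scatter) and the step of no change at the digits printed from compound 2 to compound 3 (within the scatter) all stay within the scatter of repeated measurements. Compound 3 therefore stands level with compound 1 and compound 2 on the numbers shown, and nothing separates the three.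

The next compound, compound 4 `N#CC1=C(N)N(c2ccc(S(N)(=O)=O)cc2)C2=C(CCCC2)C1c1ccc(Cl)cc1Cl`, differs from compound 3 in one place: 2,4-dichlorophenyl in place of 4-methoxyphenyl on a saturated ring carbon.

Two of the measured steps concern the same place on the shared core and are the ones that bear on this change. Going from compound 1 to compound 3 and from compound 2 to compound 3 each swapped the aromatic group on that saturated ring carbon, and neither swap moved this assay beyond its scatter. Three different aromatic groups at this place have so far given the same reading. On that basis the expected step is a number 2 percentage points lower from compound 3 to compound 4 (within the scatter), with no movement beyond the scatter in either direction. For compound 4 the estimate in this assay is 98%, expected to fall between 85% and 100%.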

Compound 4, a percentage reported as activity, at one concentration (the size of the read-out at that concentration, not a potency): 70%
Beside the measured number, compound 4's estimate is 28 percentage points above it, and the stated range ends above it.
By their numbers in this assay, from the lowest: compound 4; then compounds 1, 2 and 3 (each within the scatter of the next).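

In this assay, changing the aromatic group on the saturated ring carbon can move the reading after all: 2,4-dichlorophenyl gives a number 30 percentage points lower from compound 3 to compound 4 (beyond the scatter) and a number 30 percentage points lower from compound 2 to compound 4 (beyond the scatter) as well as a number 30 percentage points lower from compound 1 to compound 4 (beyond the scatter) with the same size in each case. Going by these compounds alone, the level readings of the three earlier compounds therefore did not mean that any aromatic group works equally well at this place, and the first group to lower the reading is also the first here with chlorine on the ring and no oxygen on it. Nothing measured here says what lies behind this fall.

Going by these compounds, whether the fall needs both chlorines stays open, and a 4-chlorophenyl, a 2-chlorophenyl or a plain phenyl at this carbon would help to separate the effect of each chlorine from that of losing the oxygen. All the readings also come from a single concentration, with three of them at the top of the scale, so they leave open whether compound 1, compound 2 and compound 3 would differ in the strength of their effect at a lower concentration.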